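A benzyl swap in a level cytotoxicity series

The compounds below may be only part of what the source reports. "The series", "measured", "known", "first", "only" and "open" are said of these compounds alone.

- compound 1 `Cc1cn([C@@H]2O[C@H](CO[Si](C)(C)C(C)(C)C)[C@@]3(OS(=O)(=O)C=C3N)[C@H]2O[Si](C)(C)C(C)(C)C)c(=O)n(C(=O)CCCBr)c1=O` gives 11000 nM
- compound 2 `Cc1cn([C@@H]2O[C@H](CO[Si](C)(C)C(C)(C)C)[C@@]3(OS(=O)(=O)C=C3N)[C@H]2O[Si](C)(C)C(C)(C)C)c(=O)n(C(=O)CCCC(=O)N(C)C)c1=O` gives 9500 nM
- compound 3 `Cc1cn([C@@H]2O[C@H](CO[Si](C)(C)C(C)(C)C)[C@@]3(OS(=O)(=O)C=C3N)[C@H]2O[Si](C)(C)C(C)(C)C)c(=O)n(C(=O)CCCC(=O)OC(C)(C)C)c1=O` gives 11000 nM

All three numbers come from an ADME assay on CCRF-CEM cells (Homo sapiens) for cytotoxicity, with a stated time of 4 days (a higher number here means that more compound is tolerated, a lower number that less compound is tolerated), and lie within the scatter of one another. Compound 3 matches compound 1 at the digits shown, and compound 2 sits within the scatter of both.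

The next compound is compound 4 `Cc1cn([C@@H]2O[C@H](CO[Si](C)(C)C(C)(C)C)[C@@]3(OS(=O)(=O)C=C3N)[C@H]2O[Si](C)(C)C(C)(C)C)c(=O)n(C(=O)CCCC(=O)OCc2ccccc2)c1=O`, which has benzyl in place of tert-butyl on an oxygen next to a carbonyl group. Within the data shown here, no measured compound carries a benzyl group, so the series offers no direct test of this change.

Among the measured compounds shown here, three measured steps bear on it indirectly. The closest is the change at the same carbonyl carbon, a 1.2-fold higher number from compound 2 to compound 3 (0.06 log units; within the scatter), where tert-butoxy replaces dimethylamino. The two replacements of bromo at the chain carbon are also small: a 1.2-fold lower number from compound 1 to compound 2 (0.06 log units; within the scatter) and no change at the digits printed from compound 1 to compound 3 (within the scatter). All three stay within the scatter, and on that basis no step beyond the scatter is expected in this assay, in either direction.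

The expected step is a 1.1-fold lower number from compound 3 to compound 4 (0.04 log units; within the scatter), which would remain within the scatter. As far as these compounds go, the range is kept wider than the measured spread, as benzyl is untested here. For compound 4 the estimated value is 10000 nM, with an expected range from 5500 nM to 19000 nM.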

Compound 4, half-maximal cytotoxic concentration: 9200 nM
For compound 4 the middle estimate is 1.1-fold (0.04 log units) above the measured one, and the stated range covers the measured number.
By their numbers in this assay, from the lowest: compounds 4, 2, 1 and 3 (each within the scatter of the next).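

Benzyl in place of tert-butyl on an oxygen next to a carbonyl group brings one six-membered aromatic ring of carbon only into the series, and in this assay this gives a 1.2-fold lower number from compound 3 to compound 4 (0.08 log units; within the scatter) and so stays level with the tert-butyl compound. The other two comparisons agree, with benzyloxy in place of dimethylamino on a carbonyl carbon giving a 1.0-fold lower number from compound 2 to compound 4 (0.01 log units; within the scatter) and benzyloxycarbonyl in place of bromo on a saturated chain carbon giving a 1.2-fold lower number from compound 1 to compound 4 (0.08 log units; within the scatter) so that all four compounds now read as one level and this end of the chain has tolerated every group shown, the aromatic ring included. No measured evidence accounts for this level reading.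

As far as these compounds go, whether a carboxylic acid or a primary amine at the same chain end would remain on this level stays open, as does the outcome of a longer chain carrying the same benzyloxycarbonyl group. All four compounds share the core of compound 1, including its tert-butyldimethylsilyl groups, so the series gives no reading on how this assay responds to a change anywhere in that core.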